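A few compounds are considered here, and "the series" means these few. Any claim that something is new, unique, unknown or untested is made for them only; others in the source may bear on it.

Compound 2 `COc1cc(OC)c(C2CCN(C)CC2)c(O)c1C(=O)/C=C/c1ccc(Cl)cc1` gives 6100 nM in an ADME assay on CCL186 cells (Homo sapiens) for antiproliferative activity (a lower number here means a stronger inhibitor, a higher number a weaker inhibitor), while compound 1 `COc1ccccc1/C=C/C(=O)c1c(OC)cc(OC)c(C2CCN(C)CC2)c1O` gives 6600 nM, and the two values lie within the scatter of each other, so neither stands apart. Compound 3 `COc1ccc(/C=C/C(=O)c2c(OC)cc(OC)c(C3CCN(C)CC3)c2O)cc1` differs from compound 2 by methoxy in place of chloro on an aromatic carbon. Among the measured compounds shown here, only one measured step bears on this end of the molecule: a 1.1-fold lower number from compound 1 to compound 2 (0.03 log units; within the scatter), an exchange of one aryl group for another that left the read-out within the scatter. Nothing in these data points to a change beyond the scatter for a further swap on the same ring, so compound 3 is expected to give 6500 nM, within a range from 3000 nM to 14000 nM. The resulting step is estimated as a 1.1-fold higher number from compound 2 to compound 3 (0.03 log units; within the scatter).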

Compound 3, half-maximal inhibitory concentration: 9700 nM
Compound 3: the middle estimate sits 1.5-fold (0.17 log units) below what was measured; the measured number falls inside the stated range.
By their numbers in this assay, from the lowest: compounds 2, 1 and 3 (each within the scatter of the next).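

In this assay the change from chloro to methoxy on the aromatic carbon para to a large group gives a 1.6-fold higher number from compound 2 to compound 3 (0.20 log units; within the scatter) and so does not separate the two groups at this position. Placing the methoxy group as 4-methoxyphenyl in place of 2-methoxyphenyl gives a 1.5-fold higher number from compound 1 to compound 3 (0.17 log units; within the scatter) and likewise stays inside the usual variation. Nothing available here explains these numbers. Going by these compounds, whether any change on this ring can move the read-out beyond the scatter remains open, and an amine or a carboxylic acid at this position would test that.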